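The compounds below may be only part of what the source reports. "The series", "measured", "known", "first", "only" and "open" are said of these compounds alone.

The series shares one core. Compound 1 `O=C(/C=C/c1ccccc1)OC1CC2(N3CCCCC3)CC(c3ccccc3)C1C(c1ccccc1)C2` and compound 2 `CC(C)(C)C(=O)OC1CC2(N3CCCCC3)CC(c3ccccc3)C1C(c1ccccc1)C2` carry different carbonyl groups on the oxygen on a saturated carbon, compound 3 `CC(=O)OC1CC2(N3CCCCC3)CC(c3ccccc3)C1C(c1ccccc1)C2` carries an acetyl there, and compound 4 `OC1CC2(N3CCCCC3)CC(c3ccccc3)C1C(c1ccccc1)C2` carries hydrogen in place of the carbonyl group. In an ADME assay on L6 cells (Rattus norvegicus) for cytotoxicity, with a stated time of 72 h (on this read-out lower numbers stand for stronger inhibition and higher numbers for weaker inhibition), compound 1 gives 10500 nM. In this assay compound 2 gives 12000 nM, and the two numbers lie within the scatter of each other, so compound 2 cannot be set apart from compound 1. In this assay compound 3 gives "not determined" (no result reported), so no result was obtained for it. The step to compound 4 reads (hydrogen in place of (tert-butyl)carbonyl on an oxygen on a saturated carbon). Among the measured compounds shown here, only one measured step exists, a 1.1-fold higher number from compound 1 to compound 2 (0.06 log units; within the scatter), and it exchanges one carbonyl group for another rather than removing it; it stayed within the scatter. For the measured compounds named here, no measured step removes the carbonyl group altogether, so the expectation rests only on the flatness seen so far. Compound 4 is therefore expected to sit near compound 2, with no change at the digits printed from compound 2 to compound 4 (within the scatter), nothing beyond the scatter. The estimate for compound 4 in this assay is 12000 nM, in a range of 5000 nM to 28000 nM.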

Compound 4, half-maximal inhibitory concentration: 37300 nM
Estimate against measurement, compound 4: 3.1-fold (0.49 log units) below; the whole stated range lies below it.
By their numbers in this assay, from the lowest: compounds 1 and 2 (each within the scatter of the next); then compound 4.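

In this assay, among the compounds shown here, taking the carbonyl group off the oxygen on a saturated carbon is the first change at this position that moves the number beyond the scatter: a 3.1-fold higher number from compound 2 to compound 4 (0.49 log units; beyond the scatter) and a 3.6-fold higher number from compound 1 to compound 4 (0.55 log units; beyond the scatter), both modest and both towards weaker inhibition. The hydroxy compound therefore stands apart from both carbonyl-bearing compounds, whereas exchanging one carbonyl group for another, a 1.1-fold higher number from compound 1 to compound 2 (0.06 log units; within the scatter), does not separate them. Nothing available here accounts for this shift.

Steps involving compound 3 cannot be read, as it has no reported result, so the acetyl group cannot be placed relative to the larger carbonyl groups. As far as these compounds go, whether the shift follows the loss of the carbonyl group or the presence of the free hydroxy stays open, and a methyl group on the same oxygen would help to tell these apart.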